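Removing a methyl from a fused pyridine core: expected loss

The source may report more compounds than this note shows. Statements on the series, on what has been measured and on what is new or still open speak of the compounds shown alone.

Measured compounds:
compound 1 `COc1ccc(-c2cc(O)c3cccnc3n2)cc1`, 17800 nM in a functional assay on HCT-116 cells (Homo sapiens); a lower number here means a stronger inhibitor of growth, a higher number a weaker inhibitor of growth
compound 2 `COc1cccc(-c2cc(O)c3c(C)cc(C)nc3n2)c1`, 407 nM
compound 3 `COc1ccc(-c2cc(O)c3cc(C)cnc3n2)cc1`, 4170 nM

Compound 2 gives the lowest number of the three. The difference between the cores of compound 2 and compound 3 is not broken down here. From compound 3 to compound 1 the change hydrogen in place of methyl on an aromatic carbon brought a 4.3-fold higher number from compound 3 to compound 1 (0.63 log units; beyond the scatter). Compound 4 `COc1cccc(-c2cc(O)c3c(C)ccnc3n2)c1` is not yet measured; it arises from compound 2 by hydrogen in place of methyl on an aromatic carbon, the same kind of change, though here the place is next to the ring nitrogen and meta to a methyl group, whereas before it was two atoms from the ring nitrogen. Because a 4.3-fold higher number from compound 3 to compound 1 (0.63 log units; beyond the scatter) was a modest rise, a similar rise is expected, a 4.2-fold higher number from compound 2 to compound 4 (0.62 log units; beyond the scatter), giving compound 4 an estimated 1700 nM (likely range 700 nM to 4500 nM).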

Compound 4, concentration for 50% growth inhibition: 44.7 nM
Compound 4: the middle estimate sits 38-fold (1.58 log units) above what was measured; measured number below the stated range.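

In this assay, hydrogen in place of methyl on an aromatic carbon next to the ring nitrogen brought a 9.1-fold lower number from compound 2 to compound 4 (0.96 log units; beyond the scatter). The same kind of change therefore did not carry its direction or size from one core to the other: the same change on two cores in this assay, a 4.3-fold higher number (0.63 log units; beyond the scatter) from compound 3 to compound 1 and a 9.1-fold lower number (0.96 log units; beyond the scatter) from compound 2 to compound 4, 39-fold (1.59 log units) apart, beyond the scatter of two such steps

The two pairs differ both in where the methyl sits and in the rest of their structures, so these data do not show which of those differences matters, and two pairs give no rule for any further core. The compounds shown leave open how an ethyl group or an amine in place of that methyl would fare. They also leave open what replacing the remaining methyl of compound 4 with hydrogen would do.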